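Hydroxymethyl on the amide chain: outlook for compound 3

This account rests on a few compounds, and the source may have more. Where it says the series, first, only, none or still open, it means among the compounds named here.

Measured in a functional assay on HaCaT cells (Homo sapiens) for cytotoxicity, read by MTT assay, with a stated time of 48 h; a higher number here means a weaker inhibitor, a lower number a stronger inhibitor:
- compound 1 `CCn1c(C(=O)NCCO)ccc1C(CC)(CC)c1ccc(OCC(O)C(C)(C)C)c(C)c1`: 2080 nM
- compound 2 `CCn1c(C(=O)N[C@@H](C)CO)ccc1C(CC)(CC)c1ccc(OCC(O)C(C)(C)C)c(C)c1`: 2060 nM

For the measured compounds named here, only two numbers exist so far, and compound 2 at 2060 nM stands level with compound 1, within the scatter. The next structure is compound 3 `CCn1c(C(=O)N[C@H](CO)CCO)ccc1C(CC)(CC)c1ccc(OCC(O)C(C)(C)C)c(C)c1`, which differs from compound 2 as follows: hydroxymethyl in place of hydrogen on a saturated chain carbon, two bonds along the chain from an amide-type nitrogen. In words, this is hydroxymethyl in place of hydrogen on a saturated chain carbon, two bonds along the chain from an amide-type nitrogen. The same difference also reads as methyl to 2-hydroxyethyl.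

Going by the values given here, one measured step bears on this change: a 1.0-fold lower number from compound 1 to compound 2 (0.00 log units; within the scatter). That step concerns the same chain but a different group, methyl rather than hydroxymethyl, so it is only a loose guide. Among the compounds with values here, it gives no direction, and no measured compound yet carries a second hydroxyl-bearing branch on this chain. No shift beyond the scatter is therefore expected in this assay. The expected change is a 1.1-fold higher number from compound 2 to compound 3 (0.05 log units; within the scatter). For compound 3 the estimated value is 2300 nM, with an expected range of 1100 nM to 4500 nM.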

Compound 3, half-maximal inhibitory concentration: 1250 nM
Estimate against measurement, compound 3: 1.8-fold (0.26 log units) above; low and high end bracket the measured number.
By their numbers in this assay, from the lowest: compounds 3, 2 and 1 (each within the scatter of the next).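

Placing hydroxymethyl on the saturated chain carbon, two bonds along the chain from an amide-type nitrogen, gives a 1.6-fold lower number from compound 2 to compound 3 (0.22 log units; within the scatter) in this assay, so this position carries the added group without a shift that can be told from the scatter. Read against the unsubstituted chain, 2-hydroxyethyl in place of hydrogen on the saturated chain carbon bound to an amide-type nitrogen and a saturated chain carbon gives a 1.7-fold lower number from compound 1 to compound 3 (0.22 log units; within the scatter) and likewise stays within the scatter, which leaves compound 1, compound 2 and compound 3 at one level in this assay even with a second hydroxyl-bearing branch on the chain. No evidence at hand bears on this result.

Still open, as far as these compounds go, is whether any replacement of the terminal hydroxyl of the 2-hydroxyethyl group, such as an amine or a carboxylic acid, would give a step beyond the scatter. A longer chain at the same place, or the opposite configuration at the branched chain carbon, is equally unresolved by the compounds shown, so the amide chain cannot yet be said to have no bearing on this assay.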